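A few compounds are considered here, and "the series" means these few. Any claim that something is new, unique, unknown or untested is made for them only; others in the source may bear on it.

In a functional assay on Huh-7 cells (Homo sapiens) for inhibition, read by CCK-8 assay, with a stated time of 72 h (on this read-out higher numbers stand for weaker inhibition and lower numbers for stronger inhibition), compound 1 `O=C(/C=C/c1cccnc1)NCCCCCc1ccc(S(=O)(=O)Nc2ccccc2)cc1` gives 408 nM, compound 2 `O=C(/C=C/c1cccnc1)NCCCCCCc1ccc(S(=O)(=O)Nc2ccccc2)cc1` gives 112 nM, and compound 3 `Cc1ccc(NS(=O)(=O)c2cccc(CCCCCCNC(=O)/C=C/c3cccnc3)c2)cc1` gives 6.92 nM. Compound 3 therefore has the lowest number of the three and is the strongest inhibitor among them, and its gaps to both of the others lie beyond the usual scatter of repeated measurements.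

The next compound is compound 4 `Cc1cccc(NS(=O)(=O)c2cccc(CCCCCCNC(=O)/C=C/c3cccnc3)c2)c1`, which keeps the atoms of compound 3 but joins them differently: 3-methylphenyl in place of 4-methylphenyl on a sulfonamide nitrogen. In words, 3-methylphenyl stands in place of 4-methylphenyl on a sulfonamide nitrogen. Among the measured compounds shown here, no pair of measured compounds shows what this kind of change does in this assay, so there is no direct precedent for its size or direction.

The expectation rests mainly on compound 3 at 6.92 nM, since the change leaves the rest of the structure untouched. A small move towards a higher number, not beyond the scatter, is expected, and this estimated step reads a 1.6-fold higher number from compound 3 to compound 4 (0.20 log units; within the scatter). A larger loss cannot be excluded, so the expected range is wider on the upper side. For compound 4 the estimated value in this assay is 11 nM, with an expected range from 3 nM to 45 nM.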

Compound 4, half-maximal inhibitory concentration: 13.2 nM
Beside the measured number, compound 4's estimate is 1.2-fold (0.08 log units) below it; measured number inside the range.
By their numbers in this assay, from the lowest: compounds 3 and 4 (each within the scatter of the next); then compound 2; then compound 1.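

The earlier compounds shown here offered no pair differing in one place, and this pair supplies the first: in this assay, putting 3-methylphenyl in place of 4-methylphenyl on a sulfonamide nitrogen gives a 1.9-fold higher number from compound 3 to compound 4 (0.28 log units; within the scatter). That step lies within the scatter, so the two methylphenyl groups cannot be told apart here, and both compounds stay in the same low range of values on this read-out. Among the compounds shown here, this is a single pair in a single cell assay, so it describes only this exchange of two groups with identical counts of atoms, and nothing measured alongside it offers an explanation for the result.

The compounds shown leave open how the sulfonamide nitrogen tolerates groups other than methylphenyl, such as a methoxyphenyl, a chlorophenyl, a pyridyl group or a phenyl group carrying a carboxylic acid, since each of these could behave quite differently from the two tested here. They also leave open whether the same exchange would read alike with a shorter or longer chain in the molecule, or in an assay on a different cell line.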